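Benzyl aryl exchanges on the shared core toward compound 4

The source may report more compounds than this note shows. Statements on the series, on what has been measured and on what is new or still open speak of the compounds shown alone.

For the measured compounds named here, compound 3 `COc1cccc(OC)c1OCCNCCOc1ccccc1OCc1ccc([N+](=O)[O-])cc1` holds the highest of the three numbers so far, though only its gap to compound 1 lies beyond the scatter: in a functional assay on PC-3 cells (Homo sapiens) for cytotoxicity, read by sulforhodamine B assay (on this read-out higher numbers stand for weaker inhibition of growth and lower numbers for stronger inhibition of growth), compound 3 gives 43600 nM. Compound 1 `COc1cccc(OC)c1OCCNCCOc1ccccc1OCc1ccc(Cl)cc1` gives 14500 nM and compound 2 `COc1cccc(OC)c1OCCNCCOc1ccccc1OCc1ccccc1C` gives 33900 nM. The step of a 3.0-fold higher number from compound 1 to compound 3 (0.48 log units; beyond the scatter) is modest and beyond the scatter, whereas a 1.3-fold higher number from compound 2 to compound 3 (0.11 log units; within the scatter) stays within it.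

Compound 4 `COc1cccc(COc2ccccc2OCCNCCOc2c(OC)cccc2OC)c1` differs from compound 3 in one place: 3-methoxyphenyl in place of 4-nitrophenyl on a saturated chain carbon bound to an oxygen on an aromatic ring. All three measured steps touch this same position. a 2.3-fold higher number from compound 1 to compound 2 (0.37 log units; beyond the scatter) and a 3.0-fold higher number from compound 1 to compound 3 (0.48 log units; beyond the scatter) show that exchanging the aryl group on the saturated chain carbon bound to an oxygen on an aromatic ring shifts the number only modestly, and a 1.3-fold higher number from compound 2 to compound 3 (0.11 log units; within the scatter) shows no shift beyond the scatter. Going by the values given here, no measured compound carries a 3-methoxyphenyl group there, so the direction is open. Since compound 3 already sits at the upper end of the spread, a small lowering toward the other two is the more likely outcome, without confidence beyond the scatter. For compound 4 a modest lowering is expected: a 1.7-fold lower number from compound 3 to compound 4 (0.24 log units; within the scatter). Compound 4 is estimated at 25000 nM in this assay, with a range from 9000 nM to 60000 nM.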

Compound 4, concentration for total growth inhibition: 15100 nM
For compound 4 the middle estimate is 1.7-fold (0.22 log units) above the measured one; measured number inside the range.
By their numbers in this assay, from the lowest: compounds 1 and 4 (each within the scatter of the next); then compounds 2 and 3 (each within the scatter of the next).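

In this assay, 3-methoxyphenyl in place of 4-nitrophenyl on a saturated chain carbon bound to an oxygen on an aromatic ring gives a 2.9-fold lower number from compound 3 to compound 4 (0.46 log units; beyond the scatter), and in place of 2-methylphenyl it gives a 2.2-fold lower number from compound 2 to compound 4 (0.35 log units; beyond the scatter), so this position now holds a second group that stands apart from both 4-nitrophenyl and 2-methylphenyl. Against 4-chlorophenyl, the same exchange gives a 1.0-fold higher number from compound 1 to compound 4 (0.02 log units; within the scatter), which shows that the lower pair of numbers at this position is not tied to 4-chlorophenyl alone and divides the four aryl groups into two pairs, compounds 1 and 4 and compounds 2 and 3, with all steps between the pairs remaining modest. No measurement given here accounts for this division into pairs.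

Still open, from the compounds shown here alone, is whether 4-methoxyphenyl or 2-methoxyphenyl would stay with 3-methoxyphenyl, which would show how much the place of the methoxy group on the ring matters. Also open, going by these compounds, is whether a carboxylic acid or a dimethylamino group on that ring, or a longer chain between the oxygen and the ring, would move the number further than any step seen so far.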